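This account rests on a few compounds, and the source may have more. Where it says the series, first, only, none or still open, it means among the compounds named here.

In a functional assay on CHO cells for agonist activity at Free fatty acid receptor 1 (Homo sapiens), read by FLIPR and calcium flux, with a stated time of 90 s, in the presence of a further agent that is not named here (on this read-out higher numbers stand for an effect only at larger amounts of compound and lower numbers for an effect already at smaller amounts), three compounds have been measured:

compound 1 `Cc1c(C)c(-c2cccc(COc3ccc4c(c3)OC[C@H]4CC(=O)O)c2)c(C)c(C)c1OC1CCS(=O)(=O)CC1` gives 29 nM
compound 2 `Cc1cc(OCC2(O)CCS(=O)(=O)CC2)cc(C)c1-c1cccc(COc2ccc3c(c2)OC[C@H]3CC(=O)O)c1` gives 13 nM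
compound 3 `Cc1cc(OC2CCS(=O)(=O)CC2)c(F)c(C)c1-c1cccc(COc2ccc3c(c2)OC[C@H]3CC(=O)O)c1` gives 19 nM

Compound 2 has the lowest of these three numbers. Its gap to compound 3 lies within the scatter, so the two cannot be ranked; its gap to compound 1 lies beyond the scatter. Compound 4 `Cc1cc(OCCCN2CCCC2=O)cc(C)c1-c1cccc(COc2ccc3c(c2)OC[C@H]3CC(=O)O)c1` has not yet been measured. It differs from compound 2 in one place: 2-(2-oxopyrrolidin-1-yl)ethyl in place of 4-hydroxy-1,1-dioxothian-4-yl on a saturated chain carbon bound to an oxygen on an aromatic ring. The hydroxy group and the sulfur-containing ring are gone, and a lactam on a longer chain takes their place. Compound 4 is expected to show a moderately higher number in this assay than compound 2, a step of a 2.3-fold higher number from compound 2 to compound 4 (0.36 log units; beyond the scatter) that may reach just beyond the scatter. The estimate for compound 4 in this assay is 30 nM, within 8 nM to 120 nM.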

Compound 4, half-maximal effective concentration: 17 nM
For compound 4 the middle estimate is 1.8-fold (0.25 log units) above the measured one; the range from low to high includes it.
By their numbers in this assay, from the lowest: compounds 2, 4, 3 and 1 (each within the scatter of the next, the first and the last beyond it).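

In this assay the exchange of 4-hydroxy-1,1-dioxothian-4-yl for 2-(2-oxopyrrolidin-1-yl)ethyl reads as a 1.3-fold higher number from compound 2 to compound 4 (0.12 log units; within the scatter) and so lies within the scatter. At this position, then, neither the hydroxy group nor the sulfur-containing ring is needed for a number in this range, and a lactam on a longer chain serves as well. Nothing measured here says why two such different groups read alike.

Still open, from the compounds shown here alone, is whether the lactam carbonyl matters, which a plain pyrrolidine amine on the same chain would test. Also open, going by these compounds, is whether the chain length matters, which a shorter chain carrying the same lactam would test.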